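Chalcone-coumarin and chalcone-flavone hybrids: toward compound 4

A few compounds are considered here, and "the series" means these few. Any claim that something is new, unique, unknown or untested is made for them only; others in the source may bear on it.

Of the compounds shown here, three have been measured in a functional assay on U-87MG ATCC cells for antiproliferative activity against U-87 MG (Homo sapiens), read by MTT assay, with a stated time of 48 h; a lower number here means a stronger inhibitor, a higher number a weaker inhibitor. Compound 1 `O=C(/C=C/c1ccc(Oc2cc(=O)oc3ccccc23)cc1)/C=C/c1cccnc1` gives 37000 nM. Compound 2 `COc1cc(OC)c2c(=O)c(OCCCOc3ccccc3/C=C/C(=O)/C=C/c3cccc([N+](=O)[O-])c3)c(-c3cc(OC)c(OC)c(OC)c3)oc2c1` gives 7920 nM. Compound 3 `COc1cc(OC)c2c(=O)c(OCCCCOc3ccccc3/C=C/C(=O)/C=C/c3ccc(Cl)cc3)c(-c3cc(OC)c(OC)c(OC)c3)oc2c1` gives 21100 nM. On these three numbers compound 3 stands second highest; its value and that of compound 1 lie within the scatter of each other, so no order between them is claimed, whereas compound 2 sits at a lower number than compound 3 by a margin beyond the scatter. Compound 2 and compound 3 differ in more than one place, so their gap is not read as a single step.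

Compound 4 `COc1cc(OC)c2c(=O)c(OCCCCOc3ccccc3/C=C/C(=O)/C=C/c3cccc([N+](=O)[O-])c3)c(-c3cc(OC)c(OC)c(OC)c3)oc2c1` is not yet measured. It differs from compound 3 by 3-nitrophenyl in place of 4-chlorophenyl on a double-bonded chain carbon bound to a double-bonded chain carbon. For the measured compounds named here, no single-point step between measured compounds exists in this set. Going by the values given here, compound 2, which carries the same 3-nitrophenyl, gives 7920 nM and is the only lead on this change. Compound 4 is therefore expected at a somewhat lower number than compound 3, a step of a 1.6-fold lower number from compound 3 to compound 4 (0.21 log units; within the scatter) of modest size that may not clear the scatter. The estimate for compound 4 is 13000 nM, with a range from 5000 nM to 30000 nM.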

Compound 4, half-maximal inhibitory concentration: 10000 nM
For compound 4 the middle estimate is 1.3-fold (0.11 log units) above the measured one; the range from low to high includes it.
By their numbers in this assay, from the lowest: compounds 2 and 4 (each within the scatter of the next); then compounds 3 and 1 (each within the scatter of the next).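

At the place on a double-bonded chain carbon bound to a double-bonded chain carbon, the series now has its first readable single change: in this assay, 3-nitrophenyl in place of 4-chlorophenyl gives a 2.1-fold lower number from compound 3 to compound 4 (0.32 log units; beyond the scatter). Compound 2, which carries the same 3-nitrophenyl on a shorter chain, gives 7920 nM and compound 4 gives 10000 nM; these values lie within the scatter of each other, so no order is read between the two chains. No available data explain why the swap moves the number.

This single step cannot separate the nitro group from its ring position, a question that 3-chlorophenyl or 4-nitrophenyl at the same place would address. On these data alone, whether an amine such as 3-aminophenyl would hold the lower number also remains open.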